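Dropping one chloro from an inactive dichlorobenzyl ether

The source may hold more compounds than are shown below. What is called first, only, known or untested is meant among the compounds shown, and "the series" means these compounds.

Compound 1 `Cn1c(=O)[nH]c2ccc(OCc3ccccc3)cc21`, compound 2 `Cn1c(=O)[nH]c2ccc(OCc3cccc(Cl)c3)cc21`, compound 3 `Cn1c(=O)[nH]c2ccc(OCc3ccc(Cl)c(Cl)c3)cc21`; in an assay on cells for inhibition of Amine oxidase [flavin-containing] A (Homo sapiens), read by fluorescence, with stated times of 30 min and 15 min (on this read-out higher numbers stand for weaker inhibition and lower numbers for stronger inhibition), compound 1 carries the entry "not determined" (no result reported), compound 2 carries the entry "not determined" (no result reported), and compound 3 gives > 500000 nM.

Three compounds share one core and differ only in the benzyl ether. For compound 1 and compound 2 no number is available in this assay. Compound 3 is the only one with a result, and that result is a limit of the assay rather than a number, as shown by the limit of > 500000 nM in this assay, at which 1 of the 3 values shown sits. Going by the values given here, compound 3 therefore stands at the boundary where the assay stops counting, and nothing among the measured values places it elsewhere.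

The step to compound 4 `Cn1c(=O)[nH]c2ccc(OCc3ccc(Cl)cc3)cc21` is small: hydrogen in place of chloro on an aromatic carbon. Among the compounds with values here, no measured step of this kind is known here, so the size of the change cannot be read from a comparison. Given that compound 3 sits at the limit (the limit of > 500000 nM in this assay, at which 1 of the 3 values shown sits), the expectation is that the step that the limit leaves unreadable from compound 3 to compound 4 stays within the scatter, with a fair chance that the assay again reports only a limit. The estimate for compound 4 in this assay is 600000 nM, with a range from 100000 nM to 3000000 nM.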

Compound 4, half-maximal inhibitory concentration: > 500000 nM
Compound 4: a limit, no number; the forecaster's own chance of this, stated with the estimate: 70%; the middle value does not contradict the limit.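

In this assay no size can be read for the step from compound 3 to compound 4, because each of these two compounds is reported only as a limit of the assay: the limit of > 500000 nM in this assay, at which 2 of the 4 values shown sit. The compounds shown leave open whether the chloro exchanged in this step has any effect on inhibition, and whether any compound with the shared core gives a single number.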